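A few compounds are considered here, and "the series" means these few. Any claim that something is new, unique, unknown or untested is made for them only; others in the source may bear on it.

In an assay on HEK293 cells for displacement of a labelled ligand from 5-hydroxytryptamine receptor 4 (Homo sapiens), read by scintillation counting (a higher number here means a weaker inhibitor, a lower number a stronger inhibitor), compound 3 `CCN1CCC(NC(=O)c2cc(Cl)c(N)cc2OC)CC1` gives 1000 nM. Among the three measured compounds this is the second highest number: compound 2 `COc1cc(N)c(Cl)cc1C(=O)NCCN1CCNCC1` gives 1260 nM, within the scatter of compound 3, while compound 1 `COc1cc(N)c(Cl)cc1C(=O)NCC1CCNCC1` gives 316 nM, a lower number beyond the scatter. Among the measured compounds shown here, the only measured step that changes a single place is a 4.0-fold higher number from compound 1 to compound 2 (0.60 log units; beyond the scatter), a change on the saturated chain carbon bound to the amide-type nitrogen, not at the ring amine. Compound 4 `COc1cc(N)c(Cl)cc1C(=O)NC1CCN(CCN2CCCCC2)CC1` differs from compound 3 by piperidin-1-yl in place of hydrogen on a saturated chain carbon, two bonds along the chain from an amine nitrogen in a ring. No measured step touches this position, and nothing shown bears directly on it; the single measured step tells only that a change in the basic part of the side chain can move this assay beyond the scatter. The step is therefore expected to be small with an uncertain direction, estimated as a 2.0-fold lower number from compound 3 to compound 4 (0.30 log units; within the scatter). Compound 4 is estimated to give 500 nM, with a range from 120 nM to 2000 nM.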

Compound 4, inhibition constant: 251 nM
Compound 4: middle estimate off by 2.0-fold (0.30 log units), on the high side; low and high end bracket the measured number.
By their numbers in this assay, from the lowest: compounds 4 and 1 (each within the scatter of the next); then compounds 3 and 2 (each within the scatter of the next).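

In this assay the place on a saturated chain carbon, two bonds along the chain from an amine nitrogen in a ring, proves responsive: piperidin-1-yl in place of hydrogen gives a 4.0-fold lower number from compound 3 to compound 4 (0.60 log units; beyond the scatter) and so moves the number beyond the scatter, towards a stronger inhibitor. The earlier step changed only the group bound to the amide nitrogen, whereas this one shows that ethyl on the ring amine can be extended to 2-(piperidin-1-yl)ethyl with a gain rather than a loss. Nothing available gives a reason for this step.

As far as these compounds go, it remains open whether the ring itself matters, or whether an open-chain diethylamino group or a morpholin-4-yl ring at the same carbon would serve alike. The compounds shown also do not tell how a longer chain between the two nitrogens would read.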